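From Compound 3 to Compound 4: One Ring Becomes Two

The source may report more compounds than this note shows. Statements on the series, on what has been measured and on what is new or still open speak of the compounds shown alone.

In an ADME assay on microsomes from liver (Mus musculus) for metabolic stability, with a stated time of 10 min (on this read-out lower numbers stand for a less stable compound and higher numbers for a more stable compound), compound 3 (`COC[C@]1(C(=O)N2CC[C@](c3ccc(C(F)(C(F)(F)F)C(F)(F)F)cc3)(S(=O)(=O)c3ccc(F)cc3)C2)CC[C@H](C(=O)O)CC1`) gives 88%. Compound 1 (`C[C@]1(C(=O)N2CC[C@](c3ccc(C(F)(C(F)(F)F)C(F)(F)F)cc3)(S(=O)(=O)c3ccc(F)cc3)C2)CC[C@H](C(=O)O)CC1`) gives 95% in this assay, so these two results cannot be told apart. Compound 2 (`CCC[C@]1(C(=O)N2CC[C@](c3ccc(C(F)(C(F)(F)F)C(F)(F)F)cc3)(S(=O)(=O)c3ccc(F)cc3)C2)CC[C@H](C(=O)O)CC1`) adds no number, because its entry reads "not determined" (no result reported).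

Compound 4 (`O=C(O)C12CCC(C(=O)N3CC[C@](c4ccc(C(F)(C(F)(F)F)C(F)(F)F)cc4)(S(=O)(=O)c4ccc(F)cc4)C3)(CC1)CC2`) keeps the shared core of compound 3 and differs only in the group on a carbonyl carbon: a group of 11 heavy atoms (9 carbon, 2 oxygen; 2 six-membered non-aromatic rings of carbon only) in place of a group of 12 heavy atoms (9 carbon, 3 oxygen; one six-membered non-aromatic ring of carbon only), on a carbonyl carbon.

Within the data shown here, one measured step touches this same group: a number 7 percentage points lower from compound 1 to compound 3 (within the scatter). It involves a methoxy in place of hydrogen on a saturated chain carbon, so it says nothing directly about a second ring. Among the measured compounds shown here, no compound with a second ring has been measured yet, which leaves the estimate uncertain. For the measured compounds named here, that small step is the only guide, so no move beyond the usual scatter is expected. The estimated change is a number 2 percentage points higher from compound 3 to compound 4 (within the scatter). Compound 4 is expected to give about 90%, with an estimated range from 74% to 100%.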

Compound 4, percent of the compound remaining: 73%
Estimate against measurement, compound 4: 17 percentage points above; measured number outside the range, below it.
By their numbers in this assay, from the lowest: compound 4; then compounds 3 and 1 (each within the scatter of the next).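

In this assay, this position on the carbonyl carbon now shows a change that goes beyond the scatter: the two-ring group in place of 4-carboxy-1-(methoxymethyl)cyclohexyl gives a number 15 percentage points lower from compound 3 to compound 4 (beyond the scatter), and the same group in place of a one-ring group of 10 heavy atoms gives a number 22 percentage points lower from compound 1 to compound 4 (beyond the scatter). Among these compounds, both steps are modest, yet the earlier methoxy step at this position stayed within the scatter, so the two-ring group is the first change here to separate one compound from the others with a number. Nothing measured here gives a reason for the lower numbers.

On these data alone, whether they go with the second ring or with the loss of the methoxymethyl chain stays open, as both change together. Also open, as far as these compounds go, is how a two-ring group with an amine in place of the carboxylic acid would read in this assay.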